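A few compounds are considered here, and "the series" means these few. Any claim that something is new, unique, unknown or untested is made for them only; others in the source may bear on it.

Compound 1 `O=C(Nc1ccccc1F)N[C@H]1CC[C@H](Oc2ccc(F)cc2)CC1` gives 17500 nM in a functional assay on CRL2813 cells (Homo sapiens) for cytotoxicity, read by sulforhodamine B assay, with a stated time of 5 days (a higher number here means a weaker inhibitor, a lower number a stronger inhibitor), the highest of the two numbers that have been measured. Among the compounds with values here, compound 2 `O=C(Nc1cccc(C(F)(F)F)c1)N[C@H]1CC[C@H](OCc2ccc(F)cc2)CC1` gives 2650 nM in this assay, a lower number whose gap from compound 1 lies beyond the usual scatter, but the two compounds differ in more than one place, so no single step joins them. Compound 3 `O=C(Nc1ccccc1C(F)(F)F)N[C@H]1CC[C@H](Oc2ccc(F)cc2)CC1` reaches only the limit > 20000 nM in this assay, and this is a limit rather than a number. Within the data shown here, the one step that can be measured, an at least 1.1-fold higher number from compound 1 to compound 3 (0.05 log units; that floor lies within the scatter), is a floor because of the limit of > 20000 nM in this assay, at which 1 of the 3 values shown sits. Compound 4 `CSc1cccc(NC(=O)N[C@H]2CC[C@H](Oc3ccc(F)cc3)CC2)c1` differs from compound 1 by 3-(methylsulfanyl)phenyl in place of 2-fluorophenyl on an amide-type nitrogen. Among the measured compounds shown here, that change falls on the same aryl group as the step from compound 1 to compound 3, which gave only a floor, and no other measured pair isolates it, so in this assay only a modest movement is expected, in either direction. Compound 4 is estimated at 10000 nM, between 3000 nM and 25000 nM, an expected step of a 1.8-fold lower number from compound 1 to compound 4 (0.24 log units; within the scatter).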

Compound 4, half-maximal inhibitory concentration: 11100 nM
Estimate against measurement, compound 4: 1.1-fold (0.05 log units) below; measured number inside the range.
By their numbers in this assay, from the lowest: compound 2; then compounds 4 and 1 (each within the scatter of the next). At a limit, above all of these: compound 3.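

In this assay, the exchange of 2-fluorophenyl for 3-(methylsulfanyl)phenyl on the amide-type nitrogen gives a 1.6-fold lower number from compound 1 to compound 4 (0.20 log units; within the scatter), so the added sulfur and the hydrogen-bond acceptor it brings leave the number unresolved from that of compound 1. Within the data shown here, this is the first step at this position with a full size, since the earlier step gave only a floor. Compound 3 still stands at a limit and not at a number, so its trifluoromethyl change cannot be sized against this one: the limit of > 20000 nM in this assay, at which 1 of the 4 values shown sits.

From the compounds shown here alone, what an amine or a carboxylic acid on this aryl group would do remains open. Among these compounds, also open is whether the gap to compound 2 lies in its aryl group or elsewhere in the molecule, as no single step joins it to the others.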